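The compounds below may be only part of what the source reports. "The series", "measured", "known", "first", "only" and "open" are said of these compounds alone.

Working notes on the series. In a functional assay on the whole organism for inhibition, with Rattus norvegicus as the target, read by paw edema, with stated times of 30 min and 4 h, at a dose of 0.28 mmol/kg by the oral route (a higher number here means more inhibition at the dose given (going by the name of the read-out), a lower number less inhibition), compound 2 `COc1ccc(-n2nc(C(=O)Nc3ccc(C(=O)O)cc3)nc2-c2cc(OC)c(OC)c(OC)c2)cc1` gives 69%. Among the compounds with values here, the only other measured member, compound 1 `COc1ccc(-n2nc(C(N)=O)nc2-c2cc(OC)c(OC)c(OC)c2)cc1`, gives in this assay 71%, so the two stand together within the scatter, and the step of a number 2 percentage points lower from compound 1 to compound 2 (within the scatter) carries 4-carboxyphenyl in place of hydrogen on the amide-type nitrogen without a change beyond the scatter.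

Compound 3 `COc1ccc(-n2nc(C(=O)Nc3ccccc3)nc2-c2cc(OC)c(OC)c(OC)c2)cc1` differs from compound 2 by hydrogen in place of carboxy on an aromatic carbon. No measured step removes carboxy from this ring; the one step that bears on the amide end, the step from compound 1 to compound 2 at the size given above, shows that building out or leaving bare the amide-type nitrogen did not move this assay beyond the scatter. No step beyond the scatter is therefore expected here either, and the expected step is a number 1 percentage points higher from compound 2 to compound 3 (within the scatter). For compound 3 in this assay the estimate is 70%, in the range 56% to 82%.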

Compound 3, a percentage reported as inhibition, in the whole organism at one dose (the size of the read-out at that dose, not a potency): 50%
The estimate for compound 3 lay 20 percentage points above the measured number, outside the stated range (below it).
By their numbers in this assay, from the lowest: compound 3; then compounds 2 and 1 (each within the scatter of the next).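

In this assay, the carboxy group on the aromatic carbon para to a large group proves not to be a free choice: hydrogen in its place gives a number 19 percentage points lower from compound 2 to compound 3 (beyond the scatter). The flat step seen earlier on the amide-type nitrogen therefore does not extend to every aryl group, since phenyl on that nitrogen gives a number 21 percentage points lower from compound 1 to compound 3 (beyond the scatter), whereas 4-carboxyphenyl stayed within the scatter of the bare amide. Nothing available explains why removing the carboxy group lowers this number.

On these data alone, it remains open whether this level of inhibition needs the carboxy group itself or would also be reached with a hydroxy group, an amine or a methyl ester at the same place. Also open, as far as these compounds go, is how a carboxylic acid on a longer chain from the same ring would read.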